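Two amides of a pyrrolidine core and a ring swap

The compounds below may be only part of what the source reports. "The series", "measured", "known", "first", "only" and "open" are said of these compounds alone.

Measured compounds:
compound 1 `Cc1cc(C(=O)O)c(C)n1-c1cccc(C(C)(C)C)c1` gives 460 nM
compound 2 `O=C(Nc1ccccc1)C1CCN(c2ccc(Cl)c(C(F)(F)F)c2)C1` gives 1000 nM

In an assay on cells for inhibition of Palmitoleoyl-protein carboxylesterase NOTUM variant C330S (Homo sapiens), read by fluorescence, with a stated time of 40 min (on this read-out higher numbers stand for weaker inhibition and lower numbers for stronger inhibition), compound 2 stands with the higher of the two numbers, and compound 1 shows a lower number, beyond the scatter of repeated measurements. Going by the values given here, no step between measured compounds is available that would bear directly on the change studied here.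

Compound 3 `CN1CN(C(=O)C2CCN(c3ccc(Cl)c(C(F)(F)F)c3)C2)CC1=O` differs from compound 2 by a group of 7 heavy atoms (4 carbon, 2 nitrogen, 1 oxygen; one five-membered non-aromatic ring with 2 hetero atoms) in place of a group of 7 heavy atoms (6 carbon, 1 nitrogen; one six-membered aromatic ring of carbon only), on a carbonyl carbon.

Among the compounds with values here, with no measured step to lean on, a modest step towards a higher number in this assay is expected, of about a 2.5-fold higher number from compound 2 to compound 3 (0.40 log units; beyond the scatter). Compound 3 is therefore estimated at 2500 nM in this assay, with a range from 700 nM to 9000 nM.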

Compound 3, half-maximal inhibitory concentration: 1400 nM
Beside the measured number, compound 3's estimate is 1.8-fold (0.25 log units) above it; the measured number falls inside the stated range.
By their numbers in this assay, from the lowest: compound 1; then compounds 2 and 3 (each within the scatter of the next).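

Going by these compounds alone, the change on the carbonyl carbon is the first one here that can be read in one place, and in this assay it gives a 1.4-fold higher number from compound 2 to compound 3 (0.15 log units; within the scatter), so the two compounds cannot be told apart. Within these two compounds, then, neither the six-membered aromatic ring of the anilino group nor its hydrogen-bond donor is required for a value in this range, as the entering five-membered non-aromatic ring has neither. Nothing available offers an explanation for this tolerance at the position.

Going by these compounds, it remains open whether a morpholine ring or a plain dimethylamino group on the same carbonyl carbon would also stay within the scatter of compound 2. Within the data shown here, the single step also leaves open whether this tolerance would hold on a different core, such as that of compound 1.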